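The compounds below may be only part of what the source reports. "The series", "measured", "known", "first", "only" and "open" are said of these compounds alone.

In a functional assay on HepG2 cells (Homo sapiens) for cytotoxicity, read by MTT assay (a lower number here means a stronger inhibitor, a higher number a weaker inhibitor), compound 1 `COc1ccc(/C=C/C(=O)c2ccc(OC)c3c2OC(C)(C)C=C3)cc1O` gives 450 nM and compound 2 `COc1ccc(/C=C/C(=O)c2ccc(OC)c3c2OC(C)(C)C=C3)cc1OC(=O)c1ccco1` gives 370 nM, two numbers within the scatter of each other. Compound 3 `COc1ccc(/C=C/C(=O)c2ccc(OC)c3c2OC(C)(C)C=C3)cc1OS(=O)(=O)c1ccc(C)cc1` keeps the shared core and carries (4-methylphenyl)sulfonyl in place of (furan-2-yl)carbonyl on an oxygen on an aromatic ring. Among the compounds with values here, the only measured step at that oxygen, a 1.2-fold lower number from compound 1 to compound 2 (0.09 log units; within the scatter), brought in (furan-2-yl)carbonyl, so no change beyond the scatter is expected in this assay. The expected step is a 1.1-fold higher number from compound 2 to compound 3 (0.03 log units; within the scatter). Compound 3 is estimated at 400 nM, with an expected range of 170 nM to 950 nM.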

Compound 3, half-maximal inhibitory concentration: 3600 nM
Compound 3: middle estimate off by 9.0-fold (0.95 log units), on the low side; measured number above the stated range.
By their numbers in this assay, from the lowest: compounds 2 and 1 (each within the scatter of the next); then compound 3.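

In this assay the oxygen on an aromatic ring is not indifferent to what it carries: (4-methylphenyl)sulfonyl brings a 9.7-fold higher number from compound 2 to compound 3 (0.99 log units; beyond the scatter) and an 8.0-fold higher number from compound 1 to compound 3 (0.90 log units; beyond the scatter) while hydrogen and (furan-2-yl)carbonyl stay within the scatter of each other. Across these three compounds, the position therefore separates one acylated or sulfonylated form from another. Nothing available here explains this difference. On these data alone, it remains open whether the shift follows the sulfonyl link or the 4-methylphenyl ring, and how an amine or a carboxylic acid on a short chain at this oxygen would read.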